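Replacing the Propylsulfanyl Group of Compound 3

This account rests on a few compounds, and the source may have more. Where it says the series, first, only, none or still open, it means among the compounds named here.

Among the measured compounds shown here, in a functional assay on the whole organism with Rattus norvegicus as the target (a higher number here means that more compound is needed for the effect, a lower number that less compound is needed), compound 3 `CCCSCCn1c(=N)sc2cc(OC(F)(F)F)ccc21` gives 2.4 mg/kg and holds the lower of the two numbers measured so far. Compound 1 `C=CCn1c(=N)sc2cc(OC(F)(F)F)ccc21` gives 7 mg/kg as the nearest number. For compound 2 `N=c1sc2cc(OC(F)(F)F)ccc2n1Cc1ccccc1` the result is > 10 mg/kg, which is a limit of the assay and not a number.

Compound 4 `C[S+]([O-])CCn1c(=N)sc2cc(OC(F)(F)F)ccc21` differs from compound 3 in one place, and a group of 3 heavy atoms (1 carbon, 1 oxygen, 1 sulfur; no ring) in place of a group of 4 heavy atoms (3 carbon, 1 sulfur; no ring), on a saturated chain carbon, two bonds along the chain from an aromatic nitrogen describes that change. For the measured compounds named here, two measured steps bear on it, both altering the group on the saturated chain carbon bound to an aromatic nitrogen: a 2.9-fold lower number from compound 1 to compound 3 (0.46 log units; beyond the scatter) and an at least 4.1-fold lower number from compound 2 to compound 3 (0.61 log units; beyond the scatter). Neither tests this exact replacement, but both show that the group at this place matters, and the first is modest in size. Compound 4 gives up the propylsulfanyl group found in compound 3, so a modest move toward a higher number is expected. The estimated change is a 2.5-fold higher number from compound 3 to compound 4 (0.40 log units; beyond the scatter) in this assay for this replacement. For compound 4 the estimate is 6 mg/kg, with an expected range from 2 mg/kg to 14 mg/kg.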

Compound 4, dose for half-maximal effect: 1.1 mg/kg
Compound 4: middle estimate off by 5.5-fold (0.74 log units), on the high side; the measured number lies below the stated range.
By their numbers in this assay, from the lowest: compound 4; then compound 3; then compound 1. At a limit, above all of these: compound 2.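

The propylsulfanyl group turns out not to be needed for a low number in this assay: the group of 3 heavy atoms that replaces it gives a 2.2-fold lower number from compound 3 to compound 4 (0.34 log units; beyond the scatter). Against the other groups at this place, the new side chain gives a 6.4-fold lower number from compound 1 to compound 4 (0.80 log units; beyond the scatter) and an at least 9.0-fold lower number from compound 2 to compound 4 (0.95 log units; beyond the scatter), so compound 4 now holds the lowest number of the compounds shown. Compound 2 has a limit and not a number, so its step is only a floor: the limit of > 10 mg/kg in this assay, at which 1 of the 4 values shown sits.

The compounds shown leave open how an amine, a carboxylic acid or a longer chain at this place would compare in this assay. Also open, on these data alone, is whether the sulfur of the entering group matters, or whether an ether oxygen could take its place.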